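A Basic Pyrrolidine Variant of Compound 1

The source may hold more compounds than are shown below. What is called first, only, known or untested is meant among the compounds shown, and "the series" means these compounds.

compound 1, `CC1CCCN1c1ccc2cc(NC(=O)CCc3ccc(C(F)(F)F)cc3)ccc2n1`: 5 nM
compound 2, `Nc1ccc2cc(NC(=O)CCc3ccc(C(F)(F)F)cc3)ccc2n1`: 240 nM
compound 3, `O=C(CCc1ccc(C(F)(F)F)cc1)Nc1ccc2nc(N3CCC4(CCNC4)C3)ccc2c1`: 0.5 nM

In an assay on isolated protein for displacement of a labelled ligand from melanin-concentrating hormone receptor 1 (Homo sapiens) (on this read-out lower numbers stand for stronger inhibition and higher numbers for weaker inhibition), compound 1 holds the second highest of the three numbers. Taking the ring away leaves a 48-fold higher number from compound 1 to compound 2 (1.68 log units; beyond the scatter), while enlarging it to the spiro diamine gives a 10-fold lower number from compound 1 to compound 3 (1.00 log units; beyond the scatter). Compound 4, `NC1CCN(c2ccc3cc(NC(=O)CCc4ccc(C(F)(F)F)cc4)ccc3n2)C1`, differs from compound 1 by 3-aminopyrrolidin-1-yl in place of 2-methylpyrrolidin-1-yl on an aromatic carbon. The ring on the aromatic carbon is kept, and, as in compound 3, a second nitrogen with a hydrogen-bond donor is brought in. The step of a 10-fold lower number from compound 1 to compound 3 (1.00 log units; beyond the scatter) therefore bears most directly on this change, and the step of a 48-fold higher number from compound 1 to compound 2 (1.68 log units; beyond the scatter) shows that losing the ring is what costs. A modest lower number is expected, a 4.2-fold lower number from compound 1 to compound 4 (0.62 log units; beyond the scatter). Compound 4 is estimated at 1.2 nM, within 0.3 nM to 5 nM.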

Compound 4, half-maximal inhibitory concentration: 12 nM
For compound 4 the middle estimate is 10-fold (1.00 log units) below the measured one; the whole stated range lies below it.
By their numbers in this assay, from the lowest: compound 3; then compound 1; then compound 4; then compound 2.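

In this assay, 3-aminopyrrolidin-1-yl on the aromatic carbon next to the ring nitrogen does not repeat the gain of the spiro diamine, even with its hydrogen-bond donor (a 2.4-fold higher number from compound 1 to compound 4 (0.38 log units; beyond the scatter)). The second nitrogen alone therefore does not account for the number of compound 3 (a 24-fold higher number from compound 3 to compound 4 (1.38 log units; beyond the scatter)), though the ring still counts against a bare amino group (a 20-fold lower number from compound 2 to compound 4 (1.30 log units; beyond the scatter)). No supporting measurement explains these differences. On these data alone, whether a piperazine or an open-chain aminoethylamino group would behave like the 3-aminopyrrolidin-1-yl group or the spiro diamine remains open.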